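Working notes: from 4-aminophenyl to 4-methoxybenzyl

This account rests on a few compounds, and the source may have more. Where it says the series, first, only, none or still open, it means among the compounds named here.

Measured so far in a physicochemical assay for lipophilicity, read by LC-MS, using the shake flask method, in phosphate buffer, measured as octanol-water partition, with a stated time of 2 h, at pH 7.4; on this read-out higher numbers stand for higher lipophilicity and lower numbers for lower lipophilicity
- compound 1 `O=C(O)c1cccc(-n2cc(CO[C@H]3O[C@H](CO)[C@@H](O)[C@H](O)[C@@H]3O)nn2)c1` gives "not determined" (no result reported)
- compound 2 `Nc1ccc(-n2cc(CO[C@H]3O[C@H](CO)[C@@H](O)[C@H](O)[C@@H]3O)nn2)cc1` gives 0.2

Within the data shown here, compound 2 stands alone at 0.2 as the only number, so it has no rank and offers no comparison. Compound 3 `COc1ccc(Cn2cc(CO[C@H]3O[C@H](CO)[C@@H](O)[C@H](O)[C@@H]3O)nn2)cc1` has not yet been measured. It carries 4-methoxybenzyl in place of 4-aminophenyl on an aromatic nitrogen of the five-membered aromatic ring with 3 nitrogen. Among the measured compounds shown here, no measured pair shows what a change at this place does in this assay, so the expectation rests on the structural change alone and stays uncertain. The expected move is upward and modest, with an estimated size of a number 0.40 log units higher from compound 2 to compound 3 (beyond the scatter). In this assay the estimated value for compound 3 is 0.6, within an expected range of 0.1 to 1.1.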

Compound 3, distribution coefficient: -0.4
Compound 3: middle estimate off by 1.00 log units, on the high side, outside the stated range (below it).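

In this assay, among these compounds, the first readable step at this place, on an aromatic nitrogen of the five-membered aromatic ring with 3 nitrogen, is a number 0.60 log units lower from compound 2 to compound 3 (beyond the scatter), with 4-methoxybenzyl in place of 4-aminophenyl. The read-out therefore responds to a change at this position, and the entering group, with more heavy atoms and no hydrogen-bond donor, gives the lower number of the two compounds. Nothing available explains this direction.

The change alters the aromatic group, its para-free description aside, in more than one respect at once, so the shown pair cannot assign the step to the methoxy group, the amine or the added carbon link. From the compounds shown here alone, a plain benzyl group or a 4-methoxyphenyl group would separate these contributions, and their effect remains open.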